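Aryl replacement on the shared core: expectation for compound 4

A few compounds are considered here, and "the series" means these few. Any claim that something is new, unique, unknown or untested is made for them only; others in the source may bear on it.

Measured compounds in a functional assay (aorta) with Oryctolagus cuniculus as the target; on this read-out lower numbers stand for stronger inhibition and higher numbers for weaker inhibition:
compound 1 `CO/C(O)=C1\C(C)=NC(C)=C(C(=O)OCCCN2C(=O)c3ccccc3S2(=O)=O)C1c1cccc([N+](=O)[O-])c1` gives 2.6 nM
compound 2 `CCO/C(O)=C1\C(C)=NC(C)=C(C(=O)OCCCN2C(=O)c3ccccc3S2(=O)=O)C1c1cccc([N+](=O)[O-])c1` gives 1.9 nM
compound 3 `COCCO/C(O)=C1\C(C)=NC(C)=C(C(=O)OCCCN2C(=O)c3ccccc3S2(=O)=O)C1c1cccc([N+](=O)[O-])c1` gives 6.8 nM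

Compound 1 stands second highest of the three numbers in this assay; compound 2 lies closest to it and compound 3 furthest. The measured steps are a 1.4-fold lower number from compound 1 to compound 2 (0.14 log units; within the scatter), a 2.6-fold higher number from compound 1 to compound 3 (0.42 log units; beyond the scatter) and a 3.6-fold higher number from compound 2 to compound 3 (0.55 log units; beyond the scatter). All three concern the chain on the oxygen on an unsaturated carbon; none touches the saturated ring carbon of the core.

Compound 4 `CO/C(O)=C1\C(C)=NC(C)=C(C(=O)OCCCN2C(=O)c3ccccc3S2(=O)=O)C1c1ccccc1Cl` differs from compound 1 by 2-chlorophenyl in place of 3-nitrophenyl on a saturated ring carbon. Among the compounds with values here, no measured step bears on this change, so the only anchor is the value of compound 1 itself, and the direction of the step cannot be read from the series. Compound 4 is therefore expected to land near compound 1, with a step of a 1.2-fold higher number from compound 1 to compound 4 (0.06 log units; within the scatter) that may fall on either side of the scatter. The estimate for compound 4 in this assay is 3 nM, with a range from 0.8 nM to 12 nM reflecting the absence of any comparable step.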

Compound 4, half-maximal inhibitory concentration: 1.8 nM
For compound 4 the middle estimate is 1.7-fold (0.22 log units) above the measured one, within the range that was stated.
By their numbers in this assay, from the lowest: compounds 4, 2 and 1 (each within the scatter of the next); then compound 3.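

In this assay, within the data shown here, the first change at the saturated ring carbon of the core, 2-chlorophenyl in place of 3-nitrophenyl, gives a 1.4-fold lower number from compound 1 to compound 4 (0.16 log units; within the scatter) and so leaves the number unchanged within the scatter. Up to now, only the chain on the oxygen had been varied; this pair shows that the aryl group at this position can lose the 2 hydrogen-bond acceptors of 3-nitrophenyl, with 0 in 2-chlorophenyl, without a step beyond the scatter. No supporting measurement accounts for this outcome.

This single pair changes both the substituent and its place on the phenyl ring, so the two contributions stay unseparated. From the compounds shown here alone, whether plain phenyl or a saturated ring such as cyclohexyl would hold the number at this position remains open, as does whether the chain steps carry over to 2-chlorophenyl compounds.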